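Changing the Aromatic Group on the Amine Nitrogen

The source may report more compounds than this note shows. Statements on the series, on what has been measured and on what is new or still open speak of the compounds shown alone.

Compound 1: `COc1cc2ncnc(Nc3ccc(F)c(Br)c3)c2cc1OCCCCC(=O)Nc1ccc(S(N)(=O)=O)cc1` — 8020 nM
Compound 2: `COc1ccccc1Nc1ncnc2cc(OC)c(OCCCCC(=O)Nc3ccc(S(N)(=O)=O)cc3)cc12` — 24200 nM

Both compounds were tested in a functional assay on A-431 cells (Homo sapiens) for antiproliferative activity, read by MTT assay, with a stated time of 72 h; on this read-out lower numbers stand for stronger inhibition and higher numbers for weaker inhibition. Within the data shown here, compound 2 holds the highest of the two numbers measured so far; the only step between measured compounds, a 3.0-fold higher number from compound 1 to compound 2 (0.48 log units; beyond the scatter), lies beyond the scatter and separates it from compound 1.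

Compound 3, `COc1cc2ncnc(Nc3ccc(C)cc3)c2cc1OCCCCC(=O)Nc1ccc(S(N)(=O)=O)cc1`, has not yet been measured. It differs from compound 2 in one place: 4-methylphenyl in place of 2-methoxyphenyl on a nitrogen on an aromatic ring. Among the measured compounds shown here, the single measured step touching this position, a 3.0-fold higher number from compound 1 to compound 2 (0.48 log units; beyond the scatter), compared two other groups on the same nitrogen, so it shows that changes here can move the number, but gives no direct reading for a 4-methylphenyl group. On that thin basis a modest move back toward a lower number is expected, with the estimated step being a 2.0-fold lower number from compound 2 to compound 3 (0.30 log units; within the scatter). Compound 3 is therefore expected at about 12000 nM, with a range from 4000 nM to 35000 nM.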

Compound 3, half-maximal inhibitory concentration: 35500 nM
Estimate against measurement, compound 3: 3.0-fold (0.47 log units) below; measured number outside the range, above it.
By their numbers in this assay, from the lowest: compound 1; then compounds 2 and 3 (each within the scatter of the next).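

In this assay, 4-methylphenyl in place of 2-methoxyphenyl gives a 1.5-fold higher number from compound 2 to compound 3 (0.17 log units; within the scatter), so these two groups on the nitrogen cannot be told apart, even though only 2-methoxyphenyl carries a hydrogen-bond acceptor. The step from the third group, 3-bromo-4-fluorophenyl, to 4-methylphenyl is a 4.4-fold higher number from compound 1 to compound 3 (0.65 log units; beyond the scatter), so of the three groups, 3-bromo-4-fluorophenyl alone stands apart, with the lowest number. No outside evidence bears on why the numbers fall this way.

The compounds shown leave open whether the bromine, the fluorine or the two together set compound 1 apart, a question that a 3-bromophenyl or a 4-fluorophenyl group on the same nitrogen could address. As far as these compounds go, how an unsubstituted phenyl group would compare also remains open.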